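Hydroxamic acid series: aryl ketone variation against histone deacetylase 4

A few compounds are considered here, and "the series" means these few. Any claim that something is new, unique, unknown or untested is made for them only; others in the source may bear on it.

compound 1, `O=C(/C=C/c1ccc(/C=C/C(=O)c2ccc3ccccc3c2)o1)NO`: 4380 nM
compound 2, `O=C(/C=C/c1ccc(/C=C/C(=O)c2ccccc2)o1)NO`: 22800 nM

In an assay on isolated protein for inhibition of histone deacetylase 4 (Homo sapiens), read by fluorescence (on this read-out lower numbers stand for stronger inhibition and higher numbers for weaker inhibition), compound 1 gives 4380 nM and compound 2 gives 22800 nM. Compound 2 stands highest of the two numbers; its nearest neighbour is compound 1, and that gap lies beyond the usual scatter. Compound 3, `Cc1ccc(C(=O)/C=C/c2ccc(/C=C/C(=O)NO)o2)cc1`, awaits measurement in this assay. It differs from compound 2 in a single place: methyl in place of hydrogen on an aromatic carbon. Cut one bond further out, the change reads phenyl to 4-methylphenyl. For the measured compounds named here, no step between measured compounds is available for this kind of change, so the expectation rests on the two values shown, where compound 1 gives the lower number at 4380 nM. A small shift toward a lower number is expected for compound 3, a 1.5-fold lower number from compound 2 to compound 3 (0.18 log units; within the scatter), likely not clearly beyond the scatter. Compound 3 is estimated at 15000 nM, with a range from 6000 nM to 40000 nM.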

Compound 3, half-maximal inhibitory concentration: 1100 nM
Compound 3: the middle estimate sits 14-fold (1.13 log units) above what was measured, outside the stated range (below it).
By their numbers in this assay, from the lowest: compound 3; then compound 1; then compound 2.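

In this assay, one methyl in place of hydrogen on an aromatic carbon, para to a large group, gives a 21-fold lower number from compound 2 to compound 3 (1.32 log units; beyond the scatter) and so counts as a large step for the addition of a single carbon. This position on the phenyl ring of compound 2 is therefore not indifferent in this series, which the two earlier compounds, differing in the whole aryl group, could not show. Nothing available accounts for the size of this step.

From the compounds shown here alone, whether the step is specific to methyl remains open, and an ethyl, a methoxy, a chlorine or a carboxylic acid at the same place would test that. Also open, going by these compounds, is whether a methyl on the larger aryl group of compound 1 would shift the number in the same direction.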